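Chloro in Place of Methoxy: Expected Effect on Cytotoxicity

The source may hold more compounds than are shown below. What is called first, only, known or untested is meant among the compounds shown, and "the series" means these compounds.

Among the compounds with values here, compound 3 `C=CCn1c(=O)/c(=C\c2ccccc2OC)[nH]c(=O)/c1=C\c1ccccc1OC` stands highest of the three numbers so far: in a functional assay on U-937 cells (Homo sapiens) for cytotoxicity, read by CCK-8 assay, with a stated time of 72 h (on this read-out higher numbers stand for weaker inhibition and lower numbers for stronger inhibition), compound 3 gives 5100 nM. Its nearest neighbour, compound 2 `C=CCn1c(=O)/c(=C\c2cccc(Br)c2)[nH]c(=O)/c1=C\c1ccccc1OC`, gives 1100 nM in this assay, and compound 1 `COc1ccccc1/C=c1\c(=O)[nH]/c(=C/c2ccccc2Cl)c(=O)n1C` gives 100 nM. Within the data shown here, the step of a 4.6-fold higher number from compound 2 to compound 3 (0.67 log units; beyond the scatter) is the only one-place comparison available. Compound 4 `C=CCn1c(=O)/c(=C\c2ccccc2Cl)[nH]c(=O)/c1=C\c1ccccc1OC` differs from compound 3 by chloro in place of methoxy on an aromatic carbon. That change runs opposite to the change from compound 2 to compound 3, a halogen entering where methoxy leaves, so a drop toward compound 2 is expected; compound 1, which also carries a 2-chlorophenyl group but differs from compound 4 elsewhere, sits far lower still. Compound 4 is therefore expected to move by a 5.7-fold lower number from compound 3 to compound 4 (0.75 log units; beyond the scatter), giving an estimated 900 nM with a range of 300 nM to 2700 nM.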

Compound 4, half-maximal inhibitory concentration: 700 nM
Compound 4: the middle estimate sits 1.3-fold (0.11 log units) above what was measured, and the stated range covers the measured number.
By their numbers in this assay, from the lowest: compound 1; then compounds 4 and 2 (each within the scatter of the next); then compound 3.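

In this assay, chloro in place of methoxy on an aromatic carbon, ortho to a large group, gives a 7.3-fold lower number from compound 3 to compound 4 (0.86 log units; beyond the scatter) and so shows that this single change at this position matters. With 2-chlorophenyl in place of 3-bromophenyl, the result is a 1.6-fold lower number from compound 2 to compound 4 (0.20 log units; within the scatter) and leaves those two compounds unseparated. Vinyl in place of hydrogen on a saturated chain carbon bound to an aromatic nitrogen gives a 7.0-fold higher number from compound 1 to compound 4 (0.85 log units; beyond the scatter) and shows that the chain also counts while 2-chlorophenyl stays in place. The compounds shown leave open how fluoro, an amine or a carboxylic acid would behave on this aromatic carbon. No supporting measurement accounts for these steps.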